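Replacing the methyl of compound 3 with hydrogen

The source may report more compounds than this note shows. Statements on the series, on what has been measured and on what is new or still open speak of the compounds shown alone.

In a functional assay on U-373MG ATCC cells (Homo sapiens) for cytotoxicity, read by MTT assay, with a stated time of 72 h (a higher number here means a weaker inhibitor, a lower number a stronger inhibitor), compound 3 (`Cc1ccc2[nH]c3c4cn[nH]c4c4c(c3c2c1)C(=O)NC4=O`) gives > 100000 nM, which is a limit and not a number. Compound 1 (`c1ccc2[nH]c(-n3cccn3)cc2c1`) gives > 100000 nM, also a limit. Compound 3 thus stands at the limit of > 100000 nM in this assay, at which 2 of the 3 values shown sit. Compound 2 (`COc1ccc2[nH]c3c4cn[nH]c4c4c(c3c2c1)C(=O)NC4=O`) gives a true number, 51000 nM. Going by the values given here, the one measured step that bears on the next change is an at least 1.9-fold higher number from compound 2 to compound 3 (0.29 log units; that floor lies within the scatter), with methyl in place of methoxy on an aromatic carbon. Compound 4 (`O=C1NC(=O)c2c1c1[nH]ncc1c1[nH]c3ccccc3c21`) differs from compound 3 by hydrogen in place of methyl on an aromatic carbon, with hydrogen in place of methyl on an aromatic carbon. No change beyond the scatter is therefore expected, and the estimated step is an at least 1.2-fold lower number from compound 3 to compound 4 (0.09 log units; that floor lies within the scatter). Compound 4 is estimated at 80000 nM, with an expected range of 30000 nM to 150000 nM.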

Compound 4, half-maximal inhibitory concentration: > 100000 nM
Compound 4 gave a limit, no number (the forecaster's own chance of this, stated with the estimate: 55%); middle value at least 1.2-fold (0.09 log units) away from the limit.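

Compound 4, with hydrogen in place of methyl on an aromatic carbon, also gives a limit, so the step between compound 3 and compound 4 cannot be read. Hydrogen in place of methoxy gives an at least 1.9-fold higher number from compound 2 to compound 4 (0.29 log units; that floor lies within the scatter), so among these three compounds only the methoxy compound 2 gives a true number, although this floor does not separate it from compound 4. The shared core thus gathers at one limit: the limit of > 100000 nM in this assay, at which 3 of the 4 values shown sit.

On these data alone, whether an amine or a hydroxyl at this position would give a true number remains open. So does whether a longer ether such as ethoxy would.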